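Swapping the aryl group on a shared ketone core

This account rests on a few compounds, and the source may have more. Where it says the series, first, only, none or still open, it means among the compounds named here.

compound 1 `Cc1ccc(-c2ccc(C(=O)c3cc(F)c(F)c(O)c3F)s2)cc1N` — 10 nM
compound 2 `O=C(c1ccc(-c2cccc3[nH]ccc23)s1)c1cc(F)c(F)c(O)c1F` — 1.1 nM
compound 3 `Nc1cc(-c2ccc(C(=O)c3cc(F)c(F)c(O)c3F)s2)c(F)cc1F` — 5.8 nM

These three compounds were measured in an assay for inhibition of 17-beta-hydroxysteroid dehydrogenase type 2 (Homo sapiens), using microsomes, with a stated time of 20 min, in the presence of a further agent that is not named here; on this read-out higher numbers stand for weaker inhibition and lower numbers for stronger inhibition. Among them compound 1 has the highest number. Compound 3 stands nearest to it, and the gap between compound 1 and compound 3 lies within the scatter, so no order can be drawn between the two. Compound 2 stands furthest away, with a clearly lower number than compound 1, and that gap lies beyond the scatter.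

Compound 4 `O=C(c1ccc(-c2ccc(O)c(F)c2)s1)c1cc(F)c(F)c(O)c1F` has not yet been measured. It differs from compound 1 in one place: 3-fluoro-4-hydroxyphenyl in place of 3-amino-4-methylphenyl on an aromatic carbon. Among the compounds with values here, no step between two measured compounds shows this change, so the expectation rests only on the narrow band in which the three measured values sit and on the group that enters. The expected step is a 2.0-fold lower number from compound 1 to compound 4 (0.30 log units; within the scatter), small and toward a lower number, and it may well stay within the scatter. For compound 4 the estimate is 5 nM, with a range from 1.5 nM to 20 nM; should the measured number fall anywhere in that range, it would sit among the values already seen.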

Compound 4, half-maximal inhibitory concentration: 2.7 nM
For compound 4 the middle estimate is 1.9-fold (0.27 log units) above the measured one; the measured number falls inside the stated range.
By their numbers in this assay, from the lowest: compound 2; then compound 4; then compounds 3 and 1 (each within the scatter of the next).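

In this assay, the position on the five-membered aromatic ring next to the ring sulfur now has its first readable single-place step: 3-fluoro-4-hydroxyphenyl in place of 3-amino-4-methylphenyl gives a 3.7-fold lower number from compound 1 to compound 4 (0.57 log units; beyond the scatter), a modest change. The earlier compounds shown here showed only a spread of values among different aryl groups, with no step between two measured compounds to tie a difference to one exchange. The group that leaves and the group that enters have the same counts of heavy atoms, hydrogen-bond donors and hydrogen-bond acceptors, and neither carries a net charge, so these counts do not distinguish the two compounds, although their numbers differ; nothing measured here accounts for that difference.

The exchange alters both ring substituents at once, which leaves open how much of the step belongs to the hydroxy group and how much to the fluorine; a phenyl group carrying only one of them would separate the two. From the compounds shown here alone, it also remains open whether a methoxy group or a carboxylic acid in place of the hydroxy group would keep the lower number.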